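Lengthening the Ether Chain on a Shared Core

The source may hold more compounds than are shown below. What is called first, only, known or untested is meant among the compounds shown, and "the series" means these compounds.

Compound 1 `CN(C)CCNc1ccnc2cc(OCc3ccccc3)ccc12` gives 1980 nM
Compound 2 `C=CCOc1ccc2c(NCCN(C)C)ccnc2c1` gives 860 nM

In a functional assay on HCT-116 cells (Homo sapiens) for cytotoxicity, read by MTT assay, with a stated time of 48 h (on this read-out lower numbers stand for stronger inhibition and higher numbers for weaker inhibition), compound 2 holds the lower number of the pair at 860 nM and is the stronger of the two. The change to compound 3 `CCCCCCOc1ccc2c(NCCN(C)C)ccnc2c1` is pentyl in place of vinyl on a saturated chain carbon bound to an oxygen on an aromatic ring or, in other words, allyloxy to hexyloxy. Going by the values given here, one measured step bears on it: a 2.3-fold lower number from compound 1 to compound 2 (0.36 log units; beyond the scatter) for vinyl in place of phenyl at this same place. That modest step gives no direction for a pentyl, so no step beyond the scatter is expected in this assay here. The estimated move is a 1.0-fold higher number from compound 2 to compound 3 (0.02 log units; within the scatter) and no larger. Compound 3 is expected at 900 nM with an estimated range of 350 nM to 2400 nM for now.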

Compound 3, half-maximal inhibitory concentration: 850 nM
Compound 3: middle estimate off by 1.1-fold (0.02 log units), on the high side; the measured number falls inside the stated range.
By their numbers in this assay, from the lowest: compounds 3 and 2 (each within the scatter of the next); then compound 1.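

In this assay, pentyl in place of vinyl gives a 1.0-fold lower number from compound 2 to compound 3 (0.01 log units; within the scatter) and so shows that, at this place, a chain of 5 carbons in the entering group reads the same as the 2 carbons it replaces. Pentyl in place of phenyl gives a 2.3-fold lower number from compound 1 to compound 3 (0.37 log units; beyond the scatter) and so places the hexyloxy chain, like the allyloxy chain, apart from the benzyl ether of compound 1. On these data alone, how an ether chain ending in an amine or a carboxylic acid, or a chain longer than hexyl, would read here stays open. No measurement shown explains these numbers.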